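Shifting a methoxy group on a benzylamine sulfonamide

The source may hold more compounds than are shown below. What is called first, only, known or untested is meant among the compounds shown, and "the series" means these compounds.

Among the compounds with values here, compound 2 `COc1cccc(CNCCCNS(=O)(=O)c2cc(C(F)(F)F)cc(C(F)(F)F)c2)c1` gives 10000 nM in a functional assay on PANC-1 cells (Homo sapiens) for inhibition, read by MTT assay, with a stated time of 72 h (a lower number here means a stronger inhibitor of growth, a higher number a weaker inhibitor of growth), and stands at the low end of the two numbers recorded, though its only neighbour, compound 1 `COc1ccc(CNCCCNS(=O)(=O)c2cc(C(F)(F)F)cc(C(F)(F)F)c2)cc1OC`, which in this assay gives 18000 nM, sits within the scatter of it. Within the data shown here, the step between them, a 1.8-fold lower number from compound 1 to compound 2 (0.26 log units; within the scatter), corresponds to hydrogen in place of methoxy on an aromatic carbon and is the only measured comparison available. Compound 3 `COc1ccccc1CNCCCNS(=O)(=O)c1cc(C(F)(F)F)cc(C(F)(F)F)c1` keeps the same atoms but joins them differently: 2-methoxyphenyl in place of 3-methoxyphenyl on a saturated chain carbon bound to an amine nitrogen. Among the measured compounds shown here, no measured step moves a methoxy group from one aromatic carbon to another, so the change from compound 2 to compound 3 has no direct precedent. For the measured compounds named here, the one step that bears on it, removing the methoxy altogether, stayed within the scatter, which offers no ground to expect a large shift. A step of no more than the scatter, in no clear direction, is therefore expected from compound 2 to compound 3 in this assay, namely no change at the digits printed from compound 2 to compound 3 (within the scatter). Compound 3 is expected to give about 10000 nM in this assay, within a range from 4000 nM to 25000 nM.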

Compound 3, concentration for 50% growth inhibition: 12000 nM
Beside the measured number, compound 3's estimate is 1.2-fold (0.08 log units) below it; the range from low to high includes it.
By their numbers in this assay, from the lowest: compounds 2, 3 and 1 (each within the scatter of the next).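

In this assay, moving the methoxy group, with 2-methoxyphenyl in place of 3-methoxyphenyl on a saturated chain carbon bound to an amine nitrogen, gives a 1.2-fold higher number from compound 2 to compound 3 (0.08 log units; within the scatter), a comparison in which the group changes place rather than number, which the earlier pair did not offer. The second reading, 2-methoxyphenyl in place of 3,4-dimethoxyphenyl at that same place, gives a 1.5-fold lower number from compound 1 to compound 3 (0.18 log units; within the scatter), so the three methoxy-bearing benzyl groups shown all lie within the scatter of one another and none separates from the rest. No measurement at hand accounts for how little these changes move the number. 

The compounds shown leave open whether a group other than methoxy on this ring, such as a hydroxyl, a fluorine or a dimethylamino group, would move the number beyond the scatter. They also leave open whether any larger change elsewhere in the shared core, such as a longer chain or a nitrile in place of a trifluoromethyl, would do so, since every step here stays on the methoxy pattern of the benzyl group.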